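Swapping Nitro for Chloro on a Weak PC-3 Inhibitor

The compounds below may be only part of what the source reports. "The series", "measured", "known", "first", "only" and "open" are said of these compounds alone.

The shared core appears in compound 1 `Cc1c(C(=O)N/N=C\c2cc([N+](=O)[O-])ccc2O)oc2cccc(O)c12`. Within the data shown here, in a functional assay on PC-3 cells (Homo sapiens) for inhibition (a higher number here means a weaker inhibitor, a lower number a stronger inhibitor), compound 1 gives 17100 nM, the only plain number among the three measured compounds. Compound 2 `Cc1c(C(=O)N/N=C\c2ccc(C(F)(F)F)cc2)oc2cccc(O)c12` reaches only the limit of this assay, >= 40000 nM. Compound 3 `Cc1c(C(=O)N/N=C\c2ccc(O)c(O)c2O)oc2cccc(O)c12` likewise stops at the limit, >= 40000 nM. Among the measured compounds shown here, compound 1 therefore stands alone as the one compound with a measurable value, while the others sit at the limit of >= 40000 nM in this assay, at which 2 of the 3 values shown sit.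

Compound 4 `Cc1c(C(=O)N/N=C\c2cc(Cl)ccc2O)oc2cccc(O)c12` has not yet been measured. It differs from compound 1 by a single change: chloro in place of nitro on an aromatic carbon. For the measured compounds named here, no measured pair of compounds shares this kind of change, so there is no step to lean on. Going by the values given here, with only one measurable value in the set, the expectation is for little movement, none beyond the scatter, though a weaker result cannot be ruled out because compounds 2 and 3 sit at the limit of >= 40000 nM in this assay, at which 2 of the 3 values shown sit. Compound 4 is estimated at 20000 nM, with a range from 8000 nM to 50000 nM. The step this estimate implies is expected to be a 1.2-fold higher number from compound 1 to compound 4 (0.07 log units; within the scatter).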

Compound 4, half-maximal inhibitory concentration: 3120 nM
Estimate against measurement, compound 4: 6.4-fold (0.81 log units) above; measured number outside the range, below it.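

At the position para to a hydroxy group, nitro is not needed for inhibition: chloro in its place brings a 5.5-fold lower number from compound 1 to compound 4 (0.74 log units; beyond the scatter) in this assay and leaves the shared core unchanged. The single chlorine atom has no hydrogen-bond acceptors, so the two counted on nitro are not required for this level of inhibition. Among these compounds, this gives the first readable step in the set, showing that the position responds to change, while the other compounds stay at a limit: the limit of >= 40000 nM in this assay, at which 2 of the 4 values shown sit.

Going by these compounds, whether this gain is particular to chloro remains open, as bromo, methoxy or an amine at the same position would be needed to show how far it extends. A single step also cannot say why the number falls, and it says nothing about other positions on this ring.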